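This account rests on a few compounds, and the source may have more. Where it says the series, first, only, none or still open, it means among the compounds named here.

Working notes on a small set of shared-core analogues examined in an ADME assay for permeability, using PAMPA, with a stated time of 30 min, at pH 7.4; on this read-out lower numbers stand for lower permeability and higher numbers for higher permeability. Compound 1 is `COc1ccc(Cn2c(-c3ccccc3)c(-c3ccccc3)c3c(=N)n(CCO)cnc32)cc1`. Its reading is a limit of the assay rather than a number: in this assay compound 1 gives > 1000 10^-6 cm/s. Compound 2 is `COc1ccc(-c2c(-c3ccc(OC)cc3)n(Cc3ccccc3)c3ncn([C@@H]4CCCC[C@H]4O)c(=N)c23)cc1`. Compound 2 likewise returns only a limit in this assay, at > 1000 10^-6 cm/s. For the measured compounds named here, compound 1 therefore stands at the same limit as the one other value recorded; both readings are summed up by the limit of > 1000 10^-6 cm/s in this assay, at which 2 of the 2 values shown sit, and no ordering between compound 1 and compound 2 can be drawn from them. Going by the values given here, no measured pair differs in a single place, so no measured step is available.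

Compound 3 is `COc1ccc(Cn2c(-c3ccccc3)c(-c3ccccc3)c3c(=N)n(CC4CCCO4)cnc32)cc1` and has not yet been measured in this assay. It differs from compound 1 by oxolan-2-yl in place of hydroxymethyl on a saturated chain carbon bound to an aromatic nitrogen. Among the compounds with values here, with both recorded compounds at the limit and no measured step to lean on, no step beyond the scatter is expected from this change. The expected step from compound 1 to compound 3 is a step that the limit leaves unreadable from compound 1 to compound 3. Compound 3 is expected most likely to return the same limit again. The estimate for compound 3 in this assay is 1200 10^-6 cm/s, with a range from 600 10^-6 cm/s to 2500 10^-6 cm/s.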

Compound 3, apparent permeability: > 1000 10^-6 cm/s
Compound 3: no number, only a limit; the forecaster's own chance of this, stated with the estimate: 80%; the middle value does not contradict the limit.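

Compound 3, like compound 1, returns only a limit in this assay, so no step can be read between compound 1 and compound 3: the limit of > 1000 10^-6 cm/s in this assay, at which 3 of the 3 values shown sit. The compounds shown leave open how the three compare in this assay, and whether any change on the shared core would give a reading that is not a limit.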